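Methyl for Fluoro: Expecting Little Change in Cytotoxicity

A few compounds are considered here, and "the series" means these few. Any claim that something is new, unique, unknown or untested is made for them only; others in the source may bear on it.

Measured in a toxicity assay on MCF-10A cells (Homo sapiens) for cytotoxicity, read by MTT assay, with a stated time of 48 h; a higher number here means a weaker inhibitor, a lower number a stronger inhibitor:
Compound 1 `O=C(/C=C/c1ccc2c(c1)B(O)OC2)c1ccccc1`: 15900 nM
Compound 2 `O=C(/C=C/c1ccc2c(c1)B(O)OC2)c1ccc(F)cc1`: 11800 nM

Compound 2 shows the lower of these two numbers, but the step of a 1.3-fold lower number from compound 1 to compound 2 (0.13 log units; within the scatter) lies within the scatter, so the two compounds cannot be ranked. Compound 3 `Cc1ccc(C(=O)/C=C/c2ccc3c(c2)B(O)OC3)cc1` differs from compound 2 by methyl in place of fluoro on an aromatic carbon. For the measured compounds named here, only one measured step touches this position, from compound 1 to compound 2, and it was within the scatter. No step beyond the scatter is therefore expected in this assay. For compound 3 the estimate is 13000 nM, between 6000 nM and 30000 nM, an expected step of a 1.1-fold higher number from compound 2 to compound 3 (0.04 log units; within the scatter).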

Compound 3, half-maximal inhibitory concentration: 8300 nM
Compound 3: middle estimate off by 1.6-fold (0.19 log units), on the high side, and the stated range covers the measured number.
By their numbers in this assay, from the lowest: compounds 3, 2 and 1 (each within the scatter of the next).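

In this assay, methyl in place of fluoro on this aromatic carbon gives a 1.4-fold lower number from compound 2 to compound 3 (0.15 log units; within the scatter), and methyl in place of hydrogen gives a 1.9-fold lower number from compound 1 to compound 3 (0.28 log units; within the scatter). Hydrogen, fluoro and methyl at this position, para to a large group, therefore all lie within the scatter of one another, so compounds 1, 2 and 3 cannot be ranked. No measurement is available to explain this result. From the compounds shown here alone, whether an amine, a carboxylic acid or a longer chain at this position would move the number beyond the scatter remains open.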